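The source may hold more compounds than are shown below. What is called first, only, known or untested is meant among the compounds shown, and "the series" means these compounds.

In a functional assay on 786-0 cells (Homo sapiens) for inhibition, read by sulforhodamine B assay, with a stated time of 48 h; a higher number here means a weaker inhibitor of growth, a lower number a stronger inhibitor of growth:
Compound 1 `CC1(/C=C/c2ccc(F)cc2)C=CC(=O)O1`: 101000 nM
Compound 2 `COc1ccc(/C=C/C2(C)C=CC(=O)O2)c(OC)c1`: 108000 nM
Compound 3 `CC1(/C=C/c2ccc(O)cc2)C=CC(=O)O1`: 143000 nM

All three values lie within the scatter of one another, so compound 3 stands level with compound 1 and compound 2. Compound 4 `COc1ccc(/C=C/C2(C)C=CC(=O)O2)cc1` has methyl in place of hydrogen on an oxygen on an aromatic ring, taking hydroxy to methoxy: methyl in place of hydrogen on an oxygen on an aromatic ring. For the measured compounds named here, the one measured step that bears on this is a 1.4-fold higher number from compound 1 to compound 3 (0.15 log units; within the scatter), a change of another group on the aromatic ring. Compound 2, which also carries methoxy, gives 108000 nM. No step beyond the scatter is therefore expected in this assay. The estimated step is a 1.2-fold lower number from compound 3 to compound 4 (0.09 log units; within the scatter). For compound 4 the expected value is 115000 nM, with an estimated range of 75000 nM to 175000 nM.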

Compound 4, concentration for total growth inhibition: > 1000000 nM
Compound 4: only a limit was reported; the forecaster's own chance of this, stated with the estimate: 5%; middle value at least 8.6-fold (0.93 log units) away from the limit.
By their numbers in this assay, from the lowest: compounds 1, 2 and 3 (each within the scatter of the next). At a limit, above all of these: compound 4.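

Compound 4 is reported in this assay only as a limit: the limit of > 1000000 nM in this assay, at which 1 of the 4 values shown sits. Methyl in place of hydrogen on the oxygen gives an at least 6.9-fold higher number from compound 3 to compound 4 (0.84 log units; beyond the scatter), the first step here beyond the scatter, whereas the earlier change on the aromatic carbon, a 1.4-fold higher number from compound 1 to compound 3 (0.15 log units; within the scatter), stayed within it. Two more steps set it apart, an at least 9.9-fold higher number from compound 1 to compound 4 (0.99 log units; beyond the scatter) and an at least 9.2-fold higher number from compound 2 to compound 4 (0.96 log units; beyond the scatter), the second being hydrogen in place of one methoxy, so methoxy alone does not go with the weak result.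

The limit leaves the true size of these steps open. Also open, as far as these compounds go, is whether an ethoxy group or an amine on that aromatic ring would read like compound 3 or compound 4.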